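The compounds below may be only part of what the source reports. "The series", "measured", "known", "first", "only" and "open" are said of these compounds alone.

Compound 1 `CNCc1cc(Oc2ccc3c(ccn3C(=O)Nc3cccc(C(F)(F)F)c3)c2)ncn1` stands highest of the two compounds measured in a functional assay on the whole organism (strain C57BL/6) for inhibition, with Mus musculus as the target, read by microscopy, with a stated time of 6 days, at a dose of 10 mg/kg by the oral route (a higher number here means more inhibition at the dose given (going by the name of the read-out), a lower number less inhibition), where compound 1 gives 67%. Compound 2 `CC(=O)N1CCc2c(ncnc2Oc2ccc3c(ccn3C(=O)Nc3cccc(C(F)(F)F)c3)c2)C1` gives 0% in this assay, a gap from compound 1 that lies beyond the scatter of repeated measurements. Compound 3 `C[C@@H]1NCc2ncnc(Oc3ccc4c(ccn4C(=O)Nc4cccc(C(F)(F)F)c4)c3)c21` has not yet been measured in this assay. It differs from compound 1 in one place: a group of 10 heavy atoms (7 carbon, 3 nitrogen; one five-membered non-aromatic ring with 1 hetero atom, one six-membered aromatic ring with 2 hetero atoms) in place of a group of 9 heavy atoms (6 carbon, 3 nitrogen; one six-membered aromatic ring with 2 hetero atoms), on an oxygen on an aromatic ring. For the measured compounds named here, no step between measured compounds matches this change, so the expectation rests on compound 1 alone. The hydrogen-bond donor is kept while the group is closed into a five-membered non-aromatic ring carrying one defined stereocentre, and a modest downward step is expected, a number 15 percentage points lower from compound 1 to compound 3 (beyond the scatter), small enough that it may not exceed the scatter. Compound 3 is therefore estimated to reach 52% in this assay, within a range from 15% to 80%.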

Compound 3, a percentage reported as inhibition, in the whole organism at one dose (the size of the read-out at that dose, not a potency): 41%
Estimate against measurement, compound 3: 11 percentage points above; measured number inside the range.
By their numbers in this assay, from the lowest: compound 2; then compound 3; then compound 1.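

At the group on an oxygen on an aromatic ring, replacing 6-((methylamino)methyl)pyrimidin-4-yl with the group closed into a five-membered non-aromatic ring gives a number 26 percentage points lower from compound 1 to compound 3 (beyond the scatter) in this assay. Inhibition is reduced but not lost, since compound 3 still gives 41%, and the two groups carry the same numbers of hydrogen-bond donors and acceptors, so this change in ring structure shifts the read-out with those counts held constant. Nothing measured here accounts for the lower number.

The compounds shown do not separate the ring closure from the added methyl group and its defined stereocentre, and they leave the opposite stereoisomer and the ring without a methyl group open. On these data alone, whether an open-chain aminomethyl or dimethylaminomethyl group at this place would match compound 1 also remains open.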